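Shrinking a Side Chain on Two Related Thioureas

This account rests on a few compounds, and the source may have more. Where it says the series, first, only, none or still open, it means among the compounds named here.

Compound 1, `CC(C)[C@H](NC(=S)NCc1ccccc1)c1nc2ccccc2[nH]1`, gives 57800 nM.
Compound 2, `CC(C)[C@@H](NC(=S)Nc1cc(C(F)(F)F)cc(C(F)(F)F)c1)c1nc2ccccc2[nH]1`, gives 16400 nM.
Compound 3, `C[C@H](NC(=S)NCc1ccccc1)c1nc2ccccc2[nH]1`, gives 217000 nM.

All three were tested in a functional assay on MCF7 cells (Homo sapiens) for cytotoxicity, read by MTT assay; on this read-out lower numbers stand for stronger inhibition and higher numbers for weaker inhibition. Compound 2 stands lowest of the three numbers, compound 3 highest. Compound 1 and compound 3 differ in one place, (methyl in place of isopropyl on a saturated chain carbon bound to an amide-type nitrogen and an aromatic carbon), and that change gave a 3.8-fold higher number from compound 1 to compound 3 (0.57 log units; beyond the scatter). Compound 4, `C[C@@H](NC(=S)Nc1cc(C(F)(F)F)cc(C(F)(F)F)c1)c1nc2ccccc2[nH]1`, is not yet measured; it relates to compound 2 as compound 3 relates to compound 1, the change being (methyl in place of isopropyl on a saturated chain carbon bound to an amide-type nitrogen and an aromatic carbon), made at the same place. How the core of compound 2 differs from the core of compound 1 is not broken down here. Because a 3.8-fold higher number from compound 1 to compound 3 (0.57 log units; beyond the scatter) was seen for this change once, a step of similar size is expected, a 3.5-fold higher number from compound 2 to compound 4 (0.55 log units; beyond the scatter), though one prior example is a thin basis. Compound 4 is therefore estimated at 58000 nM, likely between 20000 nM and 160000 nM.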

Compound 4, half-maximal inhibitory concentration: 10300 nM
Compound 4: middle estimate off by 5.6-fold (0.75 log units), on the high side; the whole stated range lies above it.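

Methyl in place of isopropyl gave a 1.6-fold lower number from compound 2 to compound 4 (0.20 log units; within the scatter), a step too small to count as a real difference. The change therefore did not carry over with the same effect from one core to the other: the same change on two cores in this assay, a 3.8-fold higher number (0.57 log units; beyond the scatter) from compound 1 to compound 3 and a 1.6-fold lower number (0.20 log units; within the scatter) from compound 2 to compound 4, 6.0-fold (0.78 log units) apart, beyond the scatter of two such steps

In these two pairs, the effect of this change depends on the core, but two pairs cannot set a rule for the series or show which part of the core matters, or why. On these data alone, it remains open how a longer chain or an amine on that saturated chain carbon would behave on either core. As far as these compounds go, it is equally open whether a third core would follow the pattern of compound 3 or that of compound 4.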